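This account rests on a few compounds, and the source may have more. Where it says the series, first, only, none or still open, it means among the compounds named here.

Measured in a functional assay on MCF7 cells (Homo sapiens) for antiproliferative activity (on this read-out higher numbers stand for weaker inhibition and lower numbers for stronger inhibition), each entry being a limit:

Compound 1 (`Nc1n[nH]c(N)c1/N=N/c1ccc([N+](=O)[O-])cc1`): > 100000 nM
Compound 2 (`Nc1n[nH]c(N)c1/N=N/c1cccc(O)c1`): > 100000 nM
Compound 3 (`Nc1n[nH]c(N)c1/N=N/c1cccc(C(=O)O)c1`): > 100000 nM

Compound 1 stands at > 100000 nM, which is a limit and not a number. It has no measured potency to rank against its neighbours, and the series shares a single reading: the limit of > 100000 nM in this assay, at which 3 of the 3 values shown sit.

The step followed here starts from compound 1 and leads to compound 4 (`Nc1n[nH]c(N)c1/N=N/c1ccc(C(=O)O)cc1`), which has not yet been measured. The structural difference is carboxy in place of nitro on an aromatic carbon. In words, this is carboxy in place of nitro on an aromatic carbon, para to a group of 9 heavy atoms, while the rest of the molecule stays the same.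

Among the compounds with values here, the one measured step that brings in a carboxy group is a step that the two limits leave unreadable from compound 2 to compound 3, so it offers no size to carry over. The expectation rests instead on compound 3, which also carries carboxy and gives > 100000 nM, a limit. No change beyond the usual scatter is therefore expected in this assay, and a further limit is the most likely report.

The estimated outcome is a step that the limit leaves unreadable from compound 1 to compound 4.

For compound 4 the estimate is 120000 nM, with an expected range from 50000 nM to 300000 nM.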

Compound 4, half-maximal inhibitory concentration: > 100000 nM
Compound 4: no number, only a limit (the forecaster's own chance of this, stated with the estimate: 85%); the middle value does not contradict the limit.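

Compound 1 and compound 4 are both reported only as limits in this assay, so the step between them cannot be read, and all the compounds share one reading: the limit of > 100000 nM in this assay, at which 4 of the 4 values shown sit.

The compounds shown leave open whether any change on the shared core would give a measurable potency against these cells.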